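A few compounds are considered here, and "the series" means these few. Any claim that something is new, unique, unknown or untested is made for them only; others in the source may bear on it.

Compound 1 `Cc1nc(C(=O)Nc2ccc(N3CC[C@H](N4CCC[C@@H]4C)C3)cc2C)co1` gives 10.1.
Compound 2 `Cc1cc(C(=O)Nc2ccc(N3CC[C@H](N4CCC[C@@H]4C)C3)cc2C)on1` gives 10.1.

Among the compounds with values here, in a physicochemical assay for acid dissociation, compound 2 stands level with compound 1 within the scatter, and the only measured step, no change at the digits printed from compound 1 to compound 2 (within the scatter), was flat. Compound 3 `Cc1cc(N2CC[C@H](N3CCC[C@@H]3C)C2)ccc1NC(=O)c1cc(C)n(C)n1` differs from compound 2 by 1,5-dimethyl-1H-pyrazol-3-yl in place of 3-methyl-1,2-oxazol-5-yl on a carbonyl carbon. That earlier step bears directly on this one: it also exchanged one five-membered aromatic ring with two hetero atoms for another on the carbonyl carbon, and it moved nothing beyond the scatter. The same outcome is therefore expected here, no change at the digits printed from compound 2 to compound 3 (within the scatter). Compound 3 is expected to give 10.1, with a range from 9.8 to 10.4.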

Compound 3, acid dissociation constant: 10.1
Beside the measured number, compound 3's estimate shows no gap at the digits printed, and the stated range covers the measured number.
By their numbers in this assay, from the lowest: compounds 1, 2 and 3 (each within the scatter of the next).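

In this assay, the series now extends from two oxygen-containing rings on the carbonyl carbon to 1,5-dimethyl-1H-pyrazol-3-yl, which has no oxygen and one more heavy atom, and this gave no change at the digits printed from compound 2 to compound 3 (within the scatter) and no change at the digits printed from compound 1 to compound 3 (within the scatter) at this position. Across these three five-membered aromatic rings, the read-out therefore stays flat. No evidence is available to explain this result.

The compounds shown leave open whether a non-aromatic group on the carbonyl carbon, such as a piperidine ring, or a ring bearing a carboxylic acid or an amine, would keep the value level.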